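Compound 4 against a limit in growth inhibition

The source may hold more compounds than are shown below. What is called first, only, known or untested is meant among the compounds shown, and "the series" means these compounds.

Measured in an ADME assay on BaF3 cells (Mus musculus) for cytotoxicity, read by CellTiter-Glo and CCK-8 assay, with a stated time of 72 h; on this read-out higher numbers stand for weaker inhibition of growth and lower numbers for stronger inhibition of growth:
Compound 1 `CCC(=O)NCc1ccc(C(=O)Nc2ccc(C)c(Nc3nccc(-c4cccnc4)n3)c2)cc1`: > 10000 nM
Compound 2 `C=CC(=O)N(CCN(C)C)Cc1ccc(C(=O)Nc2ccc(C)c(Nc3nccc(-c4cccnc4)n3)c2)cc1`: > 10000 nM
Compound 3 `Cc1ccc(NC(=O)c2ccc(CN(CCN(C)C)C(=O)C3CC3)cc2)cc1Nc1nccc(-c2cccnc2)n1`: > 10000 nM

Each of these readings is a limit and not a number. The three compounds sit together at the limit of > 10000 nM in this assay, at which 3 of the 3 values shown sit. Compound 3 gives > 10000 nM, which is a limit, so it cannot be ranked against the other two.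

The next compound is compound 4 `C=CC(=O)N(CCN(CC)CC)Cc1ccc(C(=O)Nc2ccc(C)c(Nc3nccc(-c4cccnc4)n3)c2)cc1`. It replaces the group on a saturated chain carbon bound to an aromatic carbon, with (2-(diethylamino)ethyl)(vinylcarbonyl)amino in place of (cyclopropylcarbonyl)(2-(dimethylamino)ethyl)amino on a saturated chain carbon bound to an aromatic carbon.

The closest measured change is a step that the two limits leave unreadable from compound 2 to compound 3, with cyclopropyl in place of vinyl on a carbonyl carbon. Two further changes at the same place are a step that the two limits leave unreadable from compound 1 to compound 2 and a step that the two limits leave unreadable from compound 1 to compound 3. None of these three has a readable size, so none offers a size to carry over.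

Compound 2 also carries the vinylcarbonyl group and gives > 10000 nM, a limit, so no change beyond the scatter is expected in this assay, in either direction. The estimated change is a step that the limit leaves unreadable from compound 3 to compound 4. For compound 4 the expected value is 12000 nM, with an estimated range from 5000 nM to 30000 nM.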

Compound 4, concentration for 50% growth inhibition: 5450 nM
For compound 4 the middle estimate is 2.2-fold (0.34 log units) above the measured one, and the stated range covers the measured number.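

In this assay, within the data shown here, compound 4 is the only one of the four compounds to give a number, 5450 nM, so a change on the saturated chain carbon bound to an aromatic carbon can now be set against a measured growth inhibition. The narrowest change, diethylamino in place of dimethylamino with the vinylcarbonyl group kept, gives an at least 1.8-fold lower number from compound 2 to compound 4 (0.26 log units; that floor lies within the scatter), and the two wider changes give an at least 1.8-fold lower number from compound 3 to compound 4 (0.26 log units; that floor lies within the scatter) and an at least 1.8-fold lower number from compound 1 to compound 4 (0.26 log units; that floor lies within the scatter), so all three steps point the same way, but each is only a floor on its size. The steps among compound 1, compound 2 and compound 3 cannot be read, since each of these compounds gives a limit and not a number: the limit of > 10000 nM in this assay, at which 3 of the 4 values shown sit.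

The compounds shown leave open how large the step from dimethylamino to diethylamino truly is, and whether it goes beyond the usual scatter at all. They also leave open what dipropylamino, or a longer chain between the amide-type nitrogen and the diethylamino group, would do in this assay, and whether cyclopropylcarbonyl paired with diethylamino would give a number as well.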